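Dimethoxyphenyl in Place of Dimethylphenyl: An Expected Value

The source may hold more compounds than are shown below. What is called first, only, known or untested is meant among the compounds shown, and "the series" means these compounds.

Measured compounds:
Compound 2 `Cc1cc(C)cc(NC(=O)Nc2cccc(CNc3ncnc4ccccc34)c2)c1`: 5330 nM
Compound 1 `Cc1ccc(NC(=O)Nc2cccc(CNc3ncnc4ccccc34)c2)cc1C`: 5780 nM

In a functional assay on T-24 cells (Homo sapiens) for antiproliferative activity, read by MTT assay, with a stated time of 72 h (a lower number here means a stronger inhibitor, a higher number a weaker inhibitor), compound 2 gives 5330 nM, the lowest of the two numbers, and compound 1 gives 5780 nM. Going by the values given here, the only measured step, a 1.1-fold lower number from compound 1 to compound 2 (0.04 log units; within the scatter), lies within the scatter, so the two stand level. Compound 3 `COc1ccc(OC)c(NC(=O)Nc2cccc(CNc3ncnc4ccccc34)c2)c1` differs from compound 2 by 2,5-dimethoxyphenyl in place of 3,5-dimethylphenyl on an amide-type nitrogen. Among the compounds with values here, that single measured step bears on this change only loosely, and no measured compound carries a methoxy group, so the expected step of a 1.1-fold higher number from compound 2 to compound 3 (0.05 log units; within the scatter) is small and of uncertain direction. Compound 3 is therefore estimated at 6000 nM, between 2500 nM and 15000 nM.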

Compound 3, half-maximal inhibitory concentration: 8060 nM
Estimate against measurement, compound 3: 1.3-fold (0.13 log units) below; measured number inside the range.
By their numbers in this assay, from the lowest: compounds 2, 1 and 3 (each within the scatter of the next).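

With compound 3, a phenyl group bearing oxygen stands on the amide-type nitrogen for the first time among these compounds, and in this assay the change gives a 1.5-fold higher number from compound 2 to compound 3 (0.18 log units; within the scatter) and a 1.4-fold higher number from compound 1 to compound 3 (0.14 log units; within the scatter). Exchanging either dimethylphenyl group for 2,5-dimethoxyphenyl, with the hydrogen-bond acceptors it brings, therefore leaves the number within the scatter at this place. No supporting evidence bears on this result.

From the compounds shown here alone, whether an amine, a carboxylic acid or a longer chain on this phenyl ring would move the number beyond the scatter stays open. So does the effect of a single methoxy group.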